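Trifluoromethylphenyl Replaces Dichloropyridyl at the Ether-Bearing Carbon

This account rests on a few compounds, and the source may have more. Where it says the series, first, only, none or still open, it means among the compounds named here.

Compound 1 `COc1cccc([C@@H](CO)O[C@H]2CCCN(Cc3ccc(C(=O)O)cc3C)[C@H]2c2ccccc2)c1`: 81000 nM
Compound 2 `Cc1cc(C(=O)O)ccc1CN1CCC[C@H](O[C@H](CO)c2cc(Cl)nc(Cl)c2)[C@@H]1c1ccccc1`: 2400 nM

Both values come from an assay on isolated protein for activation of cGMP-dependent protein kinase 1 (Homo sapiens), read by ADP-Glo, with stated times of 30 min and 2 h, in the presence of a further agent that is not named here; on this read-out lower numbers stand for an effect already at smaller amounts and higher numbers for an effect only at larger amounts of compound. Compound 2 stands at the lowest of the two numbers; its nearest neighbour is compound 1, and the step of a 34-fold lower number from compound 1 to compound 2 (1.53 log units; beyond the scatter) shows how strongly the aromatic group on the saturated chain carbon bound to an oxygen on a saturated carbon and a saturated chain carbon shapes the read-out. Compound 3 `Cc1cc(C(=O)O)ccc1CN1CCC[C@H](O[C@H](CO)c2cccc(C(F)(F)F)c2)[C@@H]1c1ccccc1` differs from compound 2 at exactly that place: 3-(trifluoromethyl)phenyl in place of 2,6-dichloropyridin-4-yl on a saturated chain carbon bound to an oxygen on a saturated carbon and a saturated chain carbon. Among the compounds with values here, the one measured step bears on this change only indirectly, since it tells that this position is sensitive but not how an all-carbon ring bearing trifluoromethyl compares with a dichloropyridyl ring. The number for compound 3 is therefore expected to rise, by an estimated 3.3-fold higher number from compound 2 to compound 3 (0.52 log units; beyond the scatter), while staying well short of compound 1. The estimate for compound 3 in this assay is 8000 nM, with a range from 2000 nM to 40000 nM.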

Compound 3, half-maximal effective concentration: 4100 nM
Compound 3: the middle estimate sits 2.0-fold (0.29 log units) above what was measured; the range from low to high includes it.
By their numbers in this assay, from the lowest: compounds 2 and 3 (each within the scatter of the next); then compound 1.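

In this assay the exchange of rings gives a 1.7-fold higher number from compound 2 to compound 3 (0.23 log units; within the scatter), which lies within the usual scatter, so these two quite different rings cannot be told apart on this read-out. With trifluoromethyl in place of methoxy on an aromatic carbon, the change is a 20-fold lower number from compound 1 to compound 3 (1.30 log units; beyond the scatter), which shows that a low number at this position needs neither the ring nitrogen nor the chlorines of compound 2, since compound 3 has none of them. Nothing measured here gives a reason for either step.

From the compounds shown here alone, it remains open whether a single chlorine, a nitrile or an amine on the phenyl ring in place of trifluoromethyl would also keep the number low. Going by these compounds, how far a ring carrying no added group would fall from compound 3 also remains unknown.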